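Replacing the imidazole of compound 3 with a methylpiperazine

The source may report more compounds than this note shows. Statements on the series, on what has been measured and on what is new or still open speak of the compounds shown alone.

Measured in a functional assay on MCF7 cells (Homo sapiens) for antiproliferative activity, read by CellTiter-Glo, with a stated time of 5 days; on this read-out lower numbers stand for stronger inhibition and higher numbers for weaker inhibition:
compound 1 `CC/C(=C(/c1ccc(/C=C/C(=O)O)cc1)c1ccc(-c2cscn2)cc1)c1ccccc1`: 120 nM
compound 2 `CC/C(=C(/c1ccc(/C=C/C(=O)O)cc1)c1ccc(-c2cn[nH]c2)cc1)c1ccccc1`: 40 nM
compound 3 `CC/C(=C(/c1ccc(/C=C/C(=O)O)cc1)c1ccc(-n2ccnc2)cc1)c1ccccc1`: 380 nM

In this assay compound 3, at 380 nM, has the highest number of the three, so it is the weakest inhibitor so far. Compound 4 `CC/C(=C(/c1ccc(/C=C/C(=O)O)cc1)c1ccc(N2CCN(C)CC2)cc1)c1ccccc1` carries 4-methylpiperazin-1-yl in place of 1H-imidazol-1-yl on an aromatic carbon.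

Swaps at this same place have already moved the number: a 3.0-fold lower number from compound 1 to compound 2 (0.48 log units; beyond the scatter), a 3.2-fold higher number from compound 1 to compound 3 (0.50 log units; beyond the scatter) and a 9.5-fold higher number from compound 2 to compound 3 (0.98 log units; beyond the scatter). Among the measured compounds shown here, all three groups compared there are aromatic, so no measured step shows what a non-aromatic ring does. Steps of that size remain possible in either direction, but no firm direction can be expected. The expected step is a 1.5-fold lower number from compound 3 to compound 4 (0.18 log units; within the scatter). For compound 4 the estimate is 250 nM, with an expected range of 60 nM to 1000 nM.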

Compound 4, half-maximal inhibitory concentration: 220 nM
The estimate for compound 4 lay 1.1-fold (0.06 log units) above the measured number; the measured number falls inside the stated range.
By their numbers in this assay, from the lowest: compound 2; then compounds 1, 4 and 3 (each within the scatter of the next, the first and the last beyond it).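

In this assay a non-aromatic ring is accepted at this position, since a 1.7-fold lower number from compound 3 to compound 4 (0.24 log units; within the scatter) and a 1.8-fold higher number from compound 1 to compound 4 (0.26 log units; within the scatter) both stay within the scatter. Aromaticity of the group is therefore not needed to match compounds 1 and 3. Only 1H-pyrazol-4-yl stands clearly apart, with a 5.5-fold higher number from compound 2 to compound 4 (0.74 log units; beyond the scatter) beyond the scatter.

No evidence here explains why compound 2 differs from compound 4. Going by these compounds, whether a morpholine or a piperazine without the methyl group would stay level with compound 4 or come closer to compound 2 remains open.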